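Replacing a Triazole with a Carboxylic Acid

A few compounds are considered here, and "the series" means these few. Any claim that something is new, unique, unknown or untested is made for them only; others in the source may bear on it.

Of the compounds shown here, three sharing one core have been tested in an in vitro ADME assay on microsomes from liver (Homo sapiens) for metabolic stability; on this read-out higher numbers stand for fast clearance and lower numbers for slow clearance. Compound 1 `COc1ccc(-c2cc(-c3ccc(S(=O)(=O)N(C)C)cc3)cnc2N)cn1` gives 98.8 mL.min-1.g-1. Compound 2 `COc1ccc(-c2cc(-c3ccc(S(N)(=O)=O)cc3)cnc2N)cn1` reaches only the limit of < 7 mL.min-1.g-1 in this assay, a floor rather than a number. Compound 3 `COc1ccc(-c2cc(-c3ccc(-n4cncn4)cc3)cnc2N)cn1` gives 8 mL.min-1.g-1. Among the two numbers available, compound 3 stands lowest, with compound 1 the nearest at a 12-fold lower number from compound 1 to compound 3 (1.09 log units; beyond the scatter); compound 2 sits at the limit of < 7 mL.min-1.g-1 in this assay, at which 1 of the 3 values shown sits. Between compound 2 and compound 3 the difference is an at least 1.1-fold higher number from compound 2 to compound 3 (0.05 log units; that floor lies within the scatter), and from compound 1 to compound 2 it is an at least 14-fold lower number from compound 1 to compound 2 (1.14 log units; beyond the scatter).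

Compound 4 `COc1ccc(-c2cc(-c3ccc(C(=O)O)cc3)cnc2N)cn1` differs from compound 3 in one place: carboxy in place of 1H-1,2,4-triazol-1-yl on an aromatic carbon. Going by the values given here, no measured step involves a carboxy group, so the expectation rests on the observation that both replacements of dimethylsulfamoyl so far gave low numbers in this assay. The expected step in this assay is a 1.1-fold lower number from compound 3 to compound 4 (0.06 log units; within the scatter), within the scatter. Compound 4 is therefore estimated to give 7 mL.min-1.g-1, with a likely range from 3 mL.min-1.g-1 to 20 mL.min-1.g-1.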

Compound 4, intrinsic clearance in microsomes: < 7 mL.min-1.g-1
Compound 4: a limit, no number (the forecaster's own chance of this, stated with the estimate: 45%); the middle value lies on the limit itself.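

Carboxy in place of dimethylsulfamoyl gives an at least 14-fold lower number from compound 1 to compound 4 (1.14 log units; beyond the scatter) in this assay, so a third group at this position now sits at the low end of the read-out, and among the four compounds only compound 1, with its dimethylsulfamoyl group, goes against this. Carboxy has no ring, yet replacing 1H-1,2,4-triazol-1-yl with it gives an at least 1.1-fold lower number from compound 3 to compound 4 (0.05 log units; that floor lies within the scatter), so a low reading here does not need a five-membered aromatic ring. The step between compound 2 and compound 4 cannot be read because each compound gives a limit and not a number: the limit of < 7 mL.min-1.g-1 in this assay, at which 2 of the 4 values shown sit.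

On these data alone, how far the true values of compound 2 and compound 4 lie under that limit remains open. Also open, as far as these compounds go, is whether a dimethylamide or a methyl ester at this position would stay low or come closer to compound 1 at 98.8 mL.min-1.g-1.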